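The source may report more compounds than this note shows. Statements on the series, on what has been measured and on what is new or still open speak of the compounds shown alone.

Of the compounds shown here, two from this series have been measured in an ADME assay on membranes from liver for displacement of a labelled ligand from Sigma intracellular receptor 2 (Rattus norvegicus), read by scintillation counting, with a stated time of 120 min; a higher number here means a weaker inhibitor, a lower number a stronger inhibitor. Compound 1, with the structure `O=C(c1ccccc1)N1CCC(N2CCc3ccccc3C(O)C2)CC1`, gives 1400 nM in this assay. Compound 2, with the structure `OC1CN(Cc2ccc(-c3ccccc3)cc2)CCc2ccccc21`, gives 760 nM in this assay. The two numbers sit close together, and the gap from compound 2 to compound 1 falls within the usual scatter of repeated measurements, so on the numbers shown the two compounds cannot be told apart with confidence.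

Compound 3, with the structure `c1ccc(-c2ccc(CN3CCc4ccccc4CC3)cc2)cc1`, has not yet been measured. The change from compound 2 to compound 3 is hydrogen in place of hydroxy on a saturated ring carbon. Going by the values given here, no pair of measured compounds shows this same change, so there is no measured step to lean on; the expectation rests on the structural change alone. Compound 3 is expected to give about 500 nM in this assay, with a plausible range from 150 nM to 1600 nM. That estimate means a step of a 1.5-fold lower number from compound 2 to compound 3 (0.18 log units; within the scatter), a modest move toward a lower number that may well stay within the scatter.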

Compound 3, inhibition constant: 120 nM
Estimate against measurement, compound 3: 4.2-fold (0.62 log units) above; the whole stated range lies above it.
By their numbers in this assay, from the lowest: compound 3; then compounds 2 and 1 (each within the scatter of the next).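

In this assay, going by these compounds alone, replacing the hydroxy with hydrogen on this saturated ring carbon gives a 6.3-fold lower number from compound 2 to compound 3 (0.80 log units; beyond the scatter), and this is the first step that can be read beyond the scatter. It shows that this position of the seven-membered ring, two ring bonds from the ring nitrogen, matters to the number, and that in this pair the hydroxy is not needed for inhibition, since the compound without it is the stronger inhibitor. The data shown offer nothing that explains why the number falls with this change.

On these data alone, this is a single pair, so it remains open whether the same swap would give a step of similar size with the large group of compound 1 on the ring nitrogen, where the hydroxy is also present. As far as these compounds go, it also remains open how this ring carbon would respond to other groups, such as a methoxy, a fluorine or an amine, which would show whether the number follows the loss of the hydroxy alone or can also change with a new group in its place.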